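This account rests on a few compounds, and the source may have more. Where it says the series, first, only, none or still open, it means among the compounds named here.

Measured so far, read in a functional assay on the whole organism for inhibition, with Rattus norvegicus as the target; a higher number here means that more compound is needed for the effect, a lower number that less compound is needed:
- compound 1 `CN(C)C(=O)n1cc(C(=O)c2ccn3c2CSC3c2cccnc2)c2ccc(Cc3ccccc3)cc21`: 0.09 mg/kg
- compound 2 `CN(C)C(=O)n1cc(C(=O)c2ccn3c2CSC3c2cccnc2)c2ccc(-c3ccccc3)cc21`: 0.03 mg/kg

Among the measured compounds shown here, compound 2 has the lowest number of the two; compound 1 sits at a higher number, the one step recorded being a 3.0-fold lower number from compound 1 to compound 2 (0.48 log units; beyond the scatter). Compound 3 `CN(C)C(=O)n1cc(C(=O)c2ccn3c2CSC3c2cccnc2)c2ccc(Sc3ccc(F)cc3)cc21` differs from compound 2 by (4-fluorophenyl)sulfanyl in place of phenyl on an aromatic carbon. For the measured compounds named here, the only measured step that bears on this is the one from compound 1 to compound 2, where a bridged ring gave the higher number; a one-atom sulfur link resembles that case more than the direct phenyl of compound 2. Compound 3 is therefore expected to land somewhat above compound 2, a step of a 2.3-fold higher number from compound 2 to compound 3 (0.37 log units; beyond the scatter), with an estimate of 0.07 mg/kg and a range from 0.025 mg/kg to 0.2 mg/kg.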

Compound 3, dose for half-maximal effect: 0.27 mg/kg
For compound 3 the middle estimate is 3.9-fold (0.59 log units) below the measured one; measured number above the stated range.
By their numbers in this assay, from the lowest: compound 2; then compound 1; then compound 3.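

In this assay, (4-fluorophenyl)sulfanyl on this aromatic carbon gives the highest number of the three groups, with a 9.0-fold higher number from compound 2 to compound 3 (0.95 log units; beyond the scatter) and a 3.0-fold higher number from compound 1 to compound 3 (0.48 log units; beyond the scatter), so a sulfur-linked aryl group is not equivalent here to benzyl. The change brings in sulfur and fluorine together, so the steps cannot be divided between them. No measurement at hand accounts for the rise.

Still open, from the compounds shown here alone, is whether phenylsulfanyl without the fluorine, or phenoxy, would sit nearer compound 2 or compound 3.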